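Swapping 2,4-dichlorophenyl for 4-fluorophenyl

The source may hold more compounds than are shown below. What is called first, only, known or untested is meant among the compounds shown, and "the series" means these compounds.

Compound 1 `Cc1cccc(Cn2cc(COc3ccc4c(=O)ccoc4c3)nn2)c1`: 22400 nM
Compound 2 `Cc1ccccc1Cn1cc(COc2ccc3c(=O)ccoc3c2)nn1`: > 100000 nM, a limit of the assay
Compound 3 `O=c1ccoc2cc(OCc3cn(Cc4ccc(Cl)cc4Cl)nn3)ccc12`: 13300 nM

These values come from a functional assay on QGY7701 cells (Homo sapiens) for cytotoxicity, read by MTT assay, with a stated time of 48 h; on this read-out lower numbers stand for stronger inhibition and higher numbers for weaker inhibition. Going by the values given here, compound 3 and compound 1 are the only two with true numbers, and they stand within the scatter of each other. Compound 2 gives only a limit.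

Compound 4 `O=c1ccoc2cc(OCc3cn(Cc4ccc(F)cc4)nn3)ccc12` has not yet been measured. It differs from compound 3 by 4-fluorophenyl in place of 2,4-dichlorophenyl on a saturated chain carbon bound to an aromatic nitrogen.

Earlier changes at this place bear on it, and they vary widely. The step of a 1.7-fold lower number from compound 1 to compound 3 (0.23 log units; within the scatter) is small, while an at least 4.4-fold higher number from compound 1 to compound 2 (0.64 log units; beyond the scatter) and an at least 7.5-fold lower number from compound 2 to compound 3 (0.87 log units; beyond the scatter) are both large. Only compound 2 departs sharply, so the mild step to compound 3 is taken as the better guide, with some risk of a large loss. The expected step is a 1.8-fold higher number from compound 3 to compound 4 (0.26 log units; within the scatter), so little real change is anticipated, leaning toward a higher number. For compound 4 the estimate is 24000 nM, with an expected range of 8000 nM to 80000 nM.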

Compound 4, half-maximal inhibitory concentration: 14400 nM
For compound 4 the middle estimate is 1.7-fold (0.22 log units) above the measured one; the range from low to high includes it.
By their numbers in this assay, from the lowest: compounds 3, 4 and 1 (each within the scatter of the next). At a limit, above all of these: compound 2.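

In this assay the change from 2,4-dichlorophenyl to 4-fluorophenyl gives a 1.1-fold higher number from compound 3 to compound 4 (0.03 log units; within the scatter), and the change from 3-methylphenyl to 4-fluorophenyl gives a 1.6-fold lower number from compound 1 to compound 4 (0.19 log units; within the scatter), so a third substituted phenyl group now joins the same cluster of values. Set against compound 2, the 4-fluorophenyl group gives an at least 6.9-fold lower number from compound 2 to compound 4 (0.84 log units; beyond the scatter), which leaves 2-methylphenyl as the one exception among the four compounds. Going by these compounds alone, that step starts from a limit of the assay, the one held by compound 2: the limit of > 100000 nM in this assay, at which 1 of the 4 values shown sits.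

On these data alone, whether a pyridine ring or a longer chain in place of the benzyl group would stay in this same cluster remains open. Why 2-methylphenyl alone stands apart also remains open, since these values give no cause for it.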